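One Chlorine Fewer on a Weakly Active Compound

The compounds below may be only part of what the source reports. "The series", "measured", "known", "first", "only" and "open" are said of these compounds alone.

Among the compounds with values here, in a functional assay on SW-620 cells (Homo sapiens) for antiproliferative activity, read by MTT assay, with a stated time of 24 h (on this read-out higher numbers stand for weaker inhibition and lower numbers for stronger inhibition), compound 3 (`COc1ccc(C(=O)/C=C/c2ccc(Cl)c(Cl)c2)c2c1C=CC(C)(C)O2`) gives 7700 nM, the only true number so far. Compound 1 (`COc1ccc(C(=O)/C=C/c2ccsc2)c2c1C=CC(C)(C)O2`) reads > 10000 nM, which is a limit of the assay. Compound 2 (`COc1ccc(C(=O)/C=C/c2cccc(Cl)c2)c2c1C=CC(C)(C)O2`) reads > 10000 nM, again a limit. Compound 4 (`COc1ccc(C(=O)/C=C/c2ccccc2Cl)c2c1C=CC(C)(C)O2`) carries 2-chlorophenyl in place of 3,4-dichlorophenyl on a double-bonded chain carbon bound to a double-bonded chain carbon. The closest guide is an at least 1.2-fold lower number from compound 2 to compound 3 (0.11 log units; that floor lies within the scatter), where chloro replaces hydrogen on an aromatic carbon, and an at least 1.2-fold lower number from compound 1 to compound 3 (0.11 log units; that floor lies within the scatter) points the same way. Both floors lie within the scatter, so they offer only a weak hint. An estimated 1.6-fold higher number from compound 3 to compound 4 (0.19 log units; within the scatter) is therefore expected, toward weaker inhibition. Compound 4 is expected near 12000 nM, within a range of 6000 nM to 30000 nM.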

Compound 4, half-maximal inhibitory concentration: > 10000 nM
Compound 4: only a limit was reported; the forecaster's own chance of this, stated with the estimate: 60%; the middle value does not contradict the limit.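

With 2-chlorophenyl at this place, the result is an at least 1.2-fold higher number from compound 3 to compound 4 (0.11 log units; that floor lies within the scatter), so this floor alone cannot size the change. Moving the single chlorine from 3-chlorophenyl to 2-chlorophenyl also brings no true number into view, and compound 3 remains the only compound with one. The steps to compound 4 from compound 1 and compound 2 cannot be read, as both ends are limits: the limit of > 10000 nM in this assay, at which 3 of the 4 values shown sit.

Going by these compounds, how far compound 1, compound 2 and compound 4 actually lie past that limit stays open. Also open, on these data alone, is whether an amine or a carboxylic acid on this aromatic ring in place of chlorine would give a readable value.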